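The compounds below may be only part of what the source reports. "The series", "measured", "known", "first", "only" and "open" are said of these compounds alone.

Measured compounds:
compound 1 `COc1cccc(-c2cc(O)c3c(C)cc(C)nc3n2)c1`, 407 nM
compound 2 `COc1ccccc1-c1cc(O)c2ccc(C)nc2n1`, 38000 nM
compound 3 `COc1ccccc1-c1cc(O)c2cccnc2n1`, 27500 nM

All three were run in a functional assay on HCT-116 cells (Homo sapiens); a lower number here means a stronger inhibitor of growth, a higher number a weaker inhibitor of growth. Compound 1 gives 407 nM and stands lowest of the three numbers. Its nearest neighbour is compound 3 with 27500 nM, and compound 2 gives 38000 nM; both gaps to compound 1 lie beyond the scatter.

Compound 2 and compound 3 share a core and differ in a single place, (hydrogen in place of methyl on an aromatic carbon). The step is a 1.4-fold lower number from compound 2 to compound 3 (0.14 log units; within the scatter). The difference between the core of compound 1 and the core of compound 2 is not broken down here.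

Compound 4 `COc1cccc(-c2cc(O)c3c(C)ccnc3n2)c1` has not yet been measured. It is related to compound 1 by hydrogen in place of methyl on an aromatic carbon. The surroundings of the place are not the same word for word as in the pair compound 2 to compound 3: in compound 1 the carbon is in addition meta to a methyl group (1 heavy atom). The change is therefore the same kind of change, not the same change.

Because the step of a 1.4-fold lower number from compound 2 to compound 3 (0.14 log units; within the scatter) lies within the scatter, the step from compound 1 to compound 4 is expected to be about as small, a 1.1-fold higher number from compound 1 to compound 4 (0.04 log units; within the scatter). On that basis compound 4 is estimated to give 450 nM in this assay, expected to fall between 200 nM and 1000 nM.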

Compound 4, concentration for 50% growth inhibition: 44.7 nM
Estimate against measurement, compound 4: 10-fold (1.00 log units) above; measured number outside the range, below it.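

In this assay, hydrogen in place of methyl on an aromatic carbon gives a 9.1-fold lower number from compound 1 to compound 4 (0.96 log units; beyond the scatter), so on this core the change is a clear gain in growth inhibition, with the modest size printed for the step. The size of the step does not carry over from one core to the other, and a within-scatter result on one core gave no safe guide to the result on the other: the same change on two cores in this assay, a 1.4-fold lower number (0.14 log units; within the scatter) from compound 2 to compound 3 and a 9.1-fold lower number (0.96 log units; beyond the scatter) from compound 1 to compound 4, 6.6-fold (0.82 log units) apart, beyond the scatter of two such steps

This shows only that the same kind of change can behave differently within the series; two pairs give no rule, and they cannot say which difference between the cores sets the size of the step, whether the methyl group to which the place is meta or something elsewhere on the core.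

The compounds shown leave open how the step would behave on further cores, and what hydrogen in place of the methyl group that remains on compound 4 would do. They also leave open how a longer chain such as ethyl, an amine or a carboxylic acid at the place next to the ring nitrogen would compare with hydrogen in compound 4, which gives 44.7 nM.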